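Swapping methyl for nitro on the sulfonyl aryl ring

A few compounds are considered here, and "the series" means these few. Any claim that something is new, unique, unknown or untested is made for them only; others in the source may bear on it.

Compound 1 `O=C1/C(=C/c2ccncc2)CN(S(=O)(=O)c2ccccc2)C/C1=C\c1ccccc1F` gives 5800 nM in the cell test
Compound 2 `Cc1ccc(S(=O)(=O)N2C/C(=C\c3ccncc3)C(=O)/C(=C/c3ccccc3F)C2)cc1` gives 9700 nM in the cell test

Among the measured compounds shown here, in a functional assay on HepG2 cells (Homo sapiens) for cytotoxicity, read by MTT assay, with a stated time of 24 h (a lower number here means a stronger inhibitor, a higher number a weaker inhibitor), compound 2 (9700 nM) cannot be told apart from compound 1 (5800 nM), the only other compound measured so far. For the measured compounds named here, the one measured step is a 1.7-fold higher number from compound 1 to compound 2 (0.22 log units; within the scatter) for methyl in place of hydrogen on an aromatic carbon.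

Compound 3 `O=C1/C(=C/c2ccncc2)CN(S(=O)(=O)c2ccc([N+](=O)[O-])cc2)C/C1=C\c1ccccc1F` has not yet been measured. It keeps the shared core of compound 2 but has nitro in place of methyl on an aromatic carbon, the change from 4-methylphenyl to 4-nitrophenyl (nitro in place of methyl on an aromatic carbon). Going by the values given here, no measured compound carries nitro, so the data give only indirect guidance. The closest evidence is that adding methyl at this place produced a 1.7-fold higher number from compound 1 to compound 2 (0.22 log units; within the scatter) as its whole effect on the number. On that basis, no step beyond the scatter is expected in this assay, and no direction can be argued with confidence. The expected step is a 1.4-fold lower number from compound 2 to compound 3 (0.14 log units; within the scatter) as a best guess. Compound 3 is estimated at 7000 nM (expected range 2500 nM to 20000 nM) in this test.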

Compound 3, half-maximal inhibitory concentration: 11300 nM
For compound 3 the middle estimate is 1.6-fold (0.21 log units) below the measured one; low and high end bracket the measured number.
By their numbers in this assay, from the lowest: compounds 1, 2 and 3 (each within the scatter of the next).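

The earlier pair compared only hydrogen with methyl at this position, the aromatic carbon para to a large group; nitro now adds a group of a different kind, with more heavy atoms and with hydrogen-bond acceptors that methyl lacks. Even so, in this assay nitro in place of methyl gives a 1.2-fold higher number from compound 2 to compound 3 (0.07 log units; within the scatter) and nitro in place of hydrogen gives a 1.9-fold higher number from compound 1 to compound 3 (0.29 log units; within the scatter) so hydrogen, methyl and nitro cannot be told apart here, and none of the three changes at this position shifts the number beyond the usual scatter. Nothing measured here offers an explanation for this lack of separation.

On these data alone, whether any group at this position can move the number beyond the scatter stays open, and an amine, a carboxylic acid or a longer chain on this aromatic carbon would test that. As far as these compounds go, all three compounds also share the same core, so it also remains open whether this insensitivity would persist with a change elsewhere on that core.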